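A few compounds are considered here, and "the series" means these few. Any claim that something is new, unique, unknown or untested is made for them only; others in the source may bear on it.

Compound 2 `C/C=C1/[C@H](O[C@@H]2O[C@H](CO)[C@@H](O)[C@H](O)[C@H]2O)OC=C(C(=O)OC)[C@H]1CC(=O)OCCC` and compound 1 `C/C=C1/[C@H](O[C@@H]2O[C@H](CO)[C@@H](O)[C@H](O)[C@H]2O)OC=C(C(=O)OC)[C@H]1CC(=O)OCCc1ccc(OC)cc1` share the same core and differ only in the step that the two limits leave unreadable from compound 1 to compound 2, which cannot be read in size. In a functional assay on SK-BR-3 cells (Homo sapiens) for antiproliferative activity, read by MTT assay, with a stated time of 72 h (a lower number here means a stronger inhibitor, a higher number a weaker inhibitor), compound 2 gives > 15000 nM, a limit of the assay rather than a number. In this assay compound 1 gives > 20000 nM, likewise a limit. For the measured compounds named here, both values thus rest at limits, the limit of > 15000 nM in this assay, at which 1 of the 2 values shown sits, and (the limit of > 20000 nM in this assay, at which 1 of the 2 values shown sits), so the one measured step offers no size and no direction. Compound 3 `C/C=C1/[C@H](O[C@@H]2O[C@H](CO)[C@@H](O)[C@H](O)[C@H]2O)OC=C(C(=O)OC)[C@H]1CC(=O)OCCc1ccc([N+](=O)[O-])cc1` differs from compound 2 by 4-nitrophenyl in place of methyl on a saturated chain carbon, two bonds along the chain from an oxygen next to a carbonyl group. Going by the values given here, no measured step bears on this change, and nothing in the numbers points beyond the scatter in either direction. Compound 3 is therefore expected to sit close to its neighbours, with the step that the limit leaves unreadable from compound 2 to compound 3 estimated as small. For compound 3 in this assay the estimate is 25000 nM, expected to fall between 8000 nM and 80000 nM, and a further limit is the most likely outcome.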

Compound 3, half-maximal inhibitory concentration: > 20000 nM
Compound 3 gave a limit, no number; the forecaster's own chance of this, stated with the estimate: 80%; the middle value does not contradict the limit.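

In this assay compound 3 gives > 20000 nM, a limit of the assay rather than a number. For the compounds shown here, no step among compound 1, compound 2 and compound 3 can be read in size or direction. The compounds shown leave open whether exchanging methyl, 4-methoxyphenyl or 4-nitrophenyl changes the activity at all.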